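The source may report more compounds than this note shows. Statements on the series, on what has been measured and on what is new or still open speak of the compounds shown alone.

Compound 1 `CC1=C(C(=O)OCC2CCCCC2)C(c2cccc(O)c2)NC(=O)N1C`: > 10000 nM
Compound 2 `CCC1=C(C(=O)OCC2CCCCC2)C(c2cccc(O)c2)NC(=O)N1`: > 10000 nM

Both entries come from an ADME assay on CEMx174 cells (Homo sapiens) for cytotoxicity (a higher number here means that more compound is tolerated, a lower number that less compound is tolerated), where neither compound gives an exact number. Compound 1 gives > 10000 nM, which is a limit of the assay and not a number. Compound 2 gives > 10000 nM, which is also a limit and not a number. Compound 2 therefore has no exact place on the scale and stands at the limit of > 10000 nM in this assay, at which 2 of the 2 values shown sit.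

The next compound to be tested is compound 3 `O=C1NC(C2CC2)=C(C(=O)OCC2CCCCC2)C(c2cccc(O)c2)N1`. It differs from compound 2 by having cyclopropyl in place of ethyl on a double-bonded ring carbon. Among the measured compounds shown here, no measured pair in this small set shows what such a change does in this assay, so there is no evidence for a direction, and no shift beyond the scatter is expected. This expectation rests on compound 2 and its limit of > 10000 nM. The expected change is a step that the limit leaves unreadable from compound 2 to compound 3. Another limit result would be the most likely outcome. For compound 3 the estimated value is 12000 nM, with an expected range of 5000 nM to 30000 nM.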

Compound 3, half-maximal cytotoxic concentration: > 10000 nM
Compound 3: no number, only a limit (the forecaster's own chance of this, stated with the estimate: 85%); the middle value is on the limit's open side.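

With cyclopropyl in place of ethyl, no step can be read from compound 2 to compound 3 in this assay, because both results are limits and not numbers: the limit of > 10000 nM in this assay, at which 3 of the 3 values shown sit.

The compounds shown leave open what concentration of each compound is cytotoxic, and whether this change makes any difference in this assay.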